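Methyl to fluoro on the pendant phenyl: compound 4

The source may hold more compounds than are shown below. What is called first, only, known or untested is meant among the compounds shown, and "the series" means these compounds.

Measured compounds in an assay on C6 glioma cells for displacement of a labelled ligand from sodium- and chloride-dependent glycine transporter 1 (Rattus norvegicus), read by scintillation counting, with stated times of 30 min and 10 min; a higher number here means a weaker inhibitor, a lower number a stronger inhibitor:
compound 1 `Cc1nnc(-c2ccc(-c3ccncc3)cc2)n1-c1ccccc1F` gives 5900 nM
compound 2 `Cc1nnc(-c2ccc(-c3ccccn3)cc2)n1-c1ccccc1F` gives 860 nM
compound 3 `CCc1nnc(-c2ccc(-c3ccccc3)cc2)n1-c1cccc(C)c1C` gives 940 nM

Compound 3 stands second highest of the three numbers. Its value and that of compound 2 lie within the scatter of each other, so no order between them is claimed; compound 1 gives a clearly higher number than compound 3, beyond the scatter.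

Compound 4 `CCc1nnc(-c2ccc(-c3ccccc3)cc2)n1-c1cccc(F)c1C` differs from compound 3 by fluoro in place of methyl on an aromatic carbon. Among the compounds with values here, the only step measured, a 6.9-fold lower number from compound 1 to compound 2 (0.84 log units; beyond the scatter), concerns a different place in the structure, the pyridinyl attached to the core, and says nothing about an exchange of methyl for fluoro on the phenyl carrying the core. Within the data shown here, no step bearing directly on this change is available.

With nothing to point either way, the change is expected to leave this assay within the scatter, as a 1.1-fold higher number from compound 3 to compound 4 (0.03 log units; within the scatter). Compound 4 is accordingly estimated at 1000 nM, with a range from 400 nM to 2500 nM.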

Compound 4, half-maximal inhibitory concentration: 630 nM
The estimate for compound 4 lay 1.6-fold (0.20 log units) above the measured number; the measured number falls inside the stated range.
By their numbers in this assay, from the lowest: compounds 4, 2 and 3 (each within the scatter of the next); then compound 1.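

In this assay the exchange of 2,3-dimethylphenyl for 3-fluoro-2-methylphenyl gives a 1.5-fold lower number from compound 3 to compound 4 (0.17 log units; within the scatter) and so makes no difference that can be told from the scatter. Within the data shown here, this is the first measured exchange on this ring, and it shows that fluoro and methyl cannot be told apart at this position, with the neighbouring methyl and the ethyl on the core left unaltered. No supporting measurement bears on why the two groups read alike.

As far as these compounds go, whether this position also accepts a larger or differently charged group, such as methoxy, trifluoromethyl or an amine, stays open. Also open, from the compounds shown here alone, is whether the same exchange reads alike in compounds that carry pyridin-2-yl in place of the outer phenyl.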